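The compounds below may be only part of what the source reports. "The series", "measured", "known", "first", "only" and "open" are said of these compounds alone.

In a physicochemical assay for solubility, tested at 500 uM (a higher number here means a more soluble compound, a lower number a less soluble compound), three compounds have been measured: compound 1 `COC(=O)c1cccc(OCc2oc(-c3ccccc3OC)nc2C)c1` gives 44100 nM; compound 2 `COC(=O)c1cccc(OCc2oc(-c3cccc(OC)c3)nc2C)c1` gives 24100 nM; compound 3 `COc1ccccc1-c1nc(C)c(COc2ccc(CCC(=O)O)cc2)o1` gives 400000 nM.

The change from compound 1 to compound 2, (3-methoxyphenyl in place of 2-methoxyphenyl on an aromatic carbon), produced a 1.8-fold lower number from compound 1 to compound 2 (0.26 log units; within the scatter). Compound 4 `COc1cccc(-c2nc(C)c(COc3ccc(CCC(=O)O)cc3)o2)c1` carries the same change relative to compound 3, (3-methoxyphenyl in place of 2-methoxyphenyl on an aromatic carbon), at the same place on the five-membered ring. The difference between the core of compound 1 and the core of compound 3 is not broken down here; their two values show compound 3 standing well above compound 1 in this assay. Because a 1.8-fold lower number from compound 1 to compound 2 (0.26 log units; within the scatter) lay within the scatter, the step from compound 3 to compound 4 is expected to be similarly modest, a 1.3-fold lower number from compound 3 to compound 4 (0.12 log units; within the scatter), with compound 3 already near the top of the range. Compound 4 is therefore estimated at 300000 nM, between 150000 nM and 500000 nM.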

Compound 4, solubility: 234000 nM
Estimate against measurement, compound 4: 1.3-fold (0.11 log units) above; measured number inside the range.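

In this assay, the change to 3-methoxyphenyl in place of 2-methoxyphenyl gave a 1.7-fold lower number from compound 3 to compound 4 (0.23 log units; within the scatter), while on the core of compound 1 the same change gave a 1.8-fold lower number from compound 1 to compound 2 (0.26 log units; within the scatter), so neither step stands clear of the scatter and, on these two cores, the change has no effect that can be read. These two pairs do not show that the change would stay this small on any other core, nor do they establish a true effect of the change on either core. Nothing available accounts for the result.

From the compounds shown here alone, it remains open whether the change would stay as small if an amine or a primary amide replaced the carboxylic acid of compound 3 and compound 4. Going by these compounds, it also remains open whether a longer chain between the carboxylic acid and the aromatic ring would alter the step.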